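The source may hold more compounds than are shown below. What is called first, only, known or untested is meant among the compounds shown, and "the series" means these compounds.

- compound 1 (`Fc1ccc(-c2ccc(-c3ccc(-c4nc5ccccc5[nH]4)cc3)cc2)cc1`) gives 39300 nM
- compound 2 (`Oc1cccc2[nH]c(-c3ccc(-c4ccc(-c5ccc(F)cc5)cc4)cc3)nc12`) gives 8310 nM

Compound 2 holds the lower of the two numbers in a functional assay on HOP-62 cells (Homo sapiens) for inhibition, read by sulforhodamine B assay (on this read-out higher numbers stand for weaker inhibition of growth and lower numbers for stronger inhibition of growth), and is the starting point here. Compound 3 (`COc1ccc(-c2ccc(-c3ccc(-c4nc5c(O)cccc5[nH]4)cc3)cc2)cc1`) differs from it by methoxy in place of fluoro on an aromatic carbon (methoxy in place of fluoro on an aromatic carbon, para to a large group). Among the compounds with values here, the only measured step, a 4.7-fold lower number from compound 1 to compound 2 (0.67 log units; beyond the scatter) (hydroxy in place of hydrogen on an aromatic carbon), concerns a different change at a different place, so it gives no direction for this one. No step beyond the scatter is therefore expected, and the estimated change is a 1.1-fold higher number from compound 2 to compound 3 (0.03 log units; within the scatter) (with wide uncertainty). For compound 3 the expected value is 9000 nM (estimated range 3000 nM to 27000 nM).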

Compound 3, concentration for 50% growth inhibition: 3210 nM
The estimate for compound 3 lay 2.8-fold (0.45 log units) above the measured number; the range from low to high includes it.
By their numbers in this assay, from the lowest: compound 3; then compound 2; then compound 1.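

In this assay, the aromatic carbon para to a large group proves responsive: 4-methoxyphenyl in place of 4-fluorophenyl gives a 2.6-fold lower number from compound 2 to compound 3 (0.41 log units; beyond the scatter) on a core that already carries the hydroxy. The earlier compounds had shown a change only at the hydroxy site, so this is a second place where a single change moves the number beyond the scatter. Nothing available explains this step. From the compounds shown here alone, whether an amine or a longer chain at this place would lower the number further remains open, as does whether the methoxy change would hold on the core of compound 1, without the hydroxy.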